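The compounds below may be only part of what the source reports. "The series", "measured", "known", "first", "only" and "open" are said of these compounds alone.

In a physicochemical assay for lipophilicity, at pH 7.4 (on this read-out lower numbers stand for lower lipophilicity and higher numbers for higher lipophilicity), the three measured compounds stand as follows:

compound 1 `CC(C)Nc1nc(NCc2ccco2)c2cccc(Cl)c2n1`: 3.96
compound 2 `CC(C)Nc1nc(NCc2ccco2)c2cc(Cl)ccc2n1`: 3.99
compound 3 `Cc1cccc2c(NCc3ccco3)nc(NC(C)C)nc12`: 3.55

Compound 1 and compound 2 are built from the same atoms joined differently; the difference between the two cores is not broken down here. Their two values lie within the scatter of each other, so nothing separates them on this read-out. Compound 3 differs from compound 1 in one place, (methyl in place of chloro on an aromatic carbon), and this change gave a number 0.41 log units lower from compound 1 to compound 3 (beyond the scatter).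

Compound 4 `Cc1ccc2nc(NC(C)C)nc(NCc3ccco3)c2c1` is not yet measured. It differs from compound 2 by methyl in place of chloro on an aromatic carbon. For the measured compounds named here, this is the same kind of change as the one from compound 1 to compound 3, though not the same: in compound 3 the methyl sits ortho to a fused ring and meta to a fused ring, while in compound 4 it sits meta to a fused ring and para to a fused ring.

Because the earlier step of this kind gave a number 0.41 log units lower from compound 1 to compound 3 (beyond the scatter), a step of a similar size is expected from compound 2 to compound 4, namely a number 0.41 log units lower from compound 2 to compound 4 (beyond the scatter). The surroundings of the change are not identical, so the expectation carries some uncertainty beyond the usual scatter. For compound 4 the value in this assay is therefore estimated at 3.58, most likely between 3.3 and 3.9.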

Compound 4, distribution coefficient: 3.63
Compound 4: middle estimate off by 0.05 log units, on the low side, and the stated range covers the measured number.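

In this assay, putting methyl in place of chloro gave a number 0.36 log units lower from compound 2 to compound 4 (beyond the scatter), while the same swap at a different place on the ring had given a number 0.41 log units lower from compound 1 to compound 3 (beyond the scatter); the two steps run in the same direction and are close in size, so in this small series the change carried over well from one arrangement of the molecule to the other. For the compounds shown here, this rests on only two pairs of compounds, however, so it shows that the step held for these two placements of the group, with everything else in the molecule kept the same, and it does not establish a general rule for this swap on other cores or at other ring carbons. Nothing measured here explains why the number falls with this swap, so the result describes what happened and gives no reason for it.

As far as these compounds go, how a methoxy or a trifluoromethyl group on the same aromatic carbons would compare with chloro and methyl remains open. From the compounds shown here alone, it is also open whether the same swap would give a step of similar size in a molecule that carries an additional amine or a carboxylic acid.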